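A few compounds are considered here, and "the series" means these few. Any claim that something is new, unique, unknown or untested is made for them only; others in the source may bear on it.

In a functional assay on K562 cells (Homo sapiens) for cytotoxicity, read by trypan blue exclusion, with a stated time of 96 h (on this read-out lower numbers stand for stronger inhibition and higher numbers for weaker inhibition), compound 1 (`COc1ccc(NS(=O)(=O)/C=C/c2c(OC)cc(OCCCC(=O)O)cc2OC)cc1[N+](=O)[O-]`) gives 100000 nM and compound 2 (`COC(=O)CNc1cc(NS(=O)(=O)/C=C/c2c(OC)cc(OC)cc2OC)ccc1OC`) gives 350 nM (the lower of the two numbers, by a gap well beyond the scatter of repeat measurements). Compound 3 (`COc1cc(OC)c(/C=C/S(=O)(=O)Nc2ccc(OC)c(NCC(=O)O)c2)c(OC)c1`) has not yet been measured. It differs from compound 2 in one place (hydrogen in place of methyl on an oxygen next to a carbonyl group): hydrogen in place of methyl on an oxygen next to a carbonyl group, which turns methoxycarbonyl into carboxy. Going by the values given here, no measured pair shows this change alone, so any forecast is loose. Among the compounds with values here, compound 1 is the only measured compound with a carboxy group and it sits at 100000 nM (though it also differs from compound 2 elsewhere). A step towards weaker inhibition in this assay beyond the scatter is therefore expected. The expected size is an 8.6-fold higher number from compound 2 to compound 3 (0.93 log units; beyond the scatter) by this estimate. Compound 3 is estimated at 3000 nM (range 300 nM to 30000 nM).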

Compound 3, half-maximal inhibitory concentration: 20 nM
Estimate against measurement, compound 3: 150-fold (2.18 log units) above; the measured number lies below the stated range.
By their numbers in this assay, from the lowest: compound 3; then compound 2; then compound 1.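

In this assay, replacing methoxycarbonyl with carboxy, that is, hydrogen in place of methyl on an oxygen next to a carbonyl group, gives an 18-fold lower number from compound 2 to compound 3 (1.24 log units; beyond the scatter), so at this position the carboxy form goes with much stronger inhibition than the methyl ester. Going by these compounds alone, this pair is the first direct reading of the change, as compound 1 also carries a carboxy group but differs from compound 3 in more than one place, so its high number says nothing about this position alone. Nothing measured here explains the size of this step.

Going by these compounds, it remains open whether a longer chain ending in a carboxylic acid, or a primary amide in place of the carboxy group, would keep this strength. On these data alone, whether the same change has a similar effect on other cores also remains open.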